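This account rests on a few compounds, and the source may have more. Where it says the series, first, only, none or still open, it means among the compounds named here.

In a functional assay on the whole organism for inhibition, with Rattus norvegicus as the target, read by paw edema, with stated times of 4 days, 1 h and 2 h, at a dose of 100 mg/kg by the oral route (on this read-out lower numbers stand for less inhibition and higher numbers for more inhibition at the one dose given (going by the name of the read-out)), compound 1 `c1ccc(-c2nc(N3CCC(c4ccccc4)CC3)c3ccccc3n2)cc1` gives 85.3%. Compound 2 `Brc1ccc2nc(-c3ccccc3)nc(N3CCC(c4ccccc4)CC3)c2c1` gives 57.6%, a change of a number 27.7 percentage points lower from compound 1 to compound 2 (beyond the scatter). Compound 3 `CC1CCN(c2nc(-c3ccccc3)nc3ccc(I)cc23)CC1` gives 56.4%, which lies within the scatter of compound 2 and beyond the scatter below compound 1. Compound 4 `Ic1ccc2nc(-c3ccccc3)nc(N3CCC(c4ccccc4)CC3)c2c1` differs from compound 3 by phenyl in place of methyl on a saturated ring carbon. Going by the values given here, no measured step shows this change; only the values of compound 2 and compound 3, which lie within the scatter of each other, bear on it, since compound 4 carries the phenyl of compound 2 on the saturated ring carbon. Because compound 2 gives 57.6% and compound 3 gives 56.4%, compound 4 is expected to show no step beyond the scatter, a number 1.6 percentage points higher from compound 3 to compound 4 (within the scatter), with an estimate of 58% ranging from 44% to 72%.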

Compound 4, a percentage reported as inhibition, in the whole organism at one dose (the size of the read-out at that dose, not a potency): 82.5%
Estimate against measurement, compound 4: 24.5 percentage points below; measured number outside the range, above it.
By their numbers in this assay, from the lowest: compounds 3 and 2 (each within the scatter of the next); then compounds 4 and 1 (each within the scatter of the next).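

Phenyl in place of methyl on a saturated ring carbon gives a number 26.1 percentage points higher from compound 3 to compound 4 (beyond the scatter) in this assay and so is the first change at this position with a step to read. With that phenyl kept, iodo in place of bromo on an aromatic carbon gives a number 24.9 percentage points higher from compound 2 to compound 4 (beyond the scatter) while iodo in place of hydrogen gives a number 2.8 percentage points lower from compound 1 to compound 4 (within the scatter) and so the two halogens do not behave alike here. Nothing available explains these steps.

Going by these compounds, whether an amine or a carboxylic acid on that saturated ring carbon would match phenyl remains open. So does whether chloro or fluoro on the aromatic carbon would follow iodo or bromo.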